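The compounds below may be only part of what the source reports. "The series", "measured", "known", "first", "only" and "open" are said of these compounds alone.

Among the measured compounds shown here, compound 2 `O=C(O)C12CCC(C(=O)N3CC[C@](c4ccc(C(F)(C(F)(F)F)C(F)(F)F)cc4)(S(=O)(=O)c4ccc(F)cc4)C3)(CC1)CC2` is the only compound of this set with a number in an ADME assay on microsomes from liver (Mus musculus) for metabolic stability, with a stated time of 10 min; a higher number here means that more of the compound is left, a lower number that less of the compound is left: there compound 2 gives 73%. Compound 1 `CC[C@]1(C(=O)O)CC[C@H](C(=O)N2CC[C@](c3ccc(C(F)(C(F)(F)F)C(F)(F)F)cc3)(S(=O)(=O)c3ccc(F)cc3)C2)CC1` has in this assay only the entry "not determined" (no result reported), so no comparison is possible. Compound 3 `O=C(O)C12CCC(C(=O)N3CC[C@](c4ccc(C(F)(C(F)(F)F)C(F)(F)F)cc4)(S(=O)(=O)c4ccc(F)cc4)C3)(CC1)OC2` has not been measured in this assay. It differs from compound 2 by a group of 11 heavy atoms (8 carbon, 3 oxygen; one six-membered non-aromatic ring of carbon only, one six-membered non-aromatic ring with 1 hetero atom) in place of a group of 11 heavy atoms (9 carbon, 2 oxygen; 2 six-membered non-aromatic rings of carbon only), on a carbonyl carbon. For the measured compounds named here, no step between measured compounds is available, so the expected change from compound 2 to compound 3 in this assay, a number 3 percentage points lower from compound 2 to compound 3 (within the scatter), is estimated as none beyond the usual scatter. Compound 3 is therefore expected to give 70%, with a range from 50% to 88%.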

Compound 3, percent of the compound remaining: 94%
The estimate for compound 3 lay 24 percentage points below the measured number; the whole stated range lies below it.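

The position on a carbonyl carbon whose other neighbours are amide-type nitrogen in a ring is not indifferent to this change. In this assay, placing one six-membered non-aromatic ring with 1 hetero atom in the group, at the same heavy-atom count, gives a number 21 percentage points higher from compound 2 to compound 3 (beyond the scatter), so a single ring atom is enough to shift this read-out. No measurement shown accounts for this step.

Going by these compounds, it remains open whether an amine nitrogen as the hetero atom would give a step of similar size. On these data alone, whether a methoxy group on that ring would preserve the step also remains open.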